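This account rests on a few compounds, and the source may have more. Where it says the series, first, only, none or still open, it means among the compounds named here.

Working notes on the chalcone amide series.

Compound 1 `O=C(CBr)Nc1ccc(C(=O)/C=C/c2ccc(Cl)cc2)cc1` is the reference point. In a functional assay on the whole organism (strain albino) for inhibition, with Rattus norvegicus as the target, read by paw edema, with stated times of 30 min and 3 h, at a dose of 100 mg/kg by the oral route (a lower number here means less inhibition, a higher number more inhibition at the dose given (going by the name of the read-out)), compound 1 gives 59%. Compound 2 `COc1ccc(/C=C/C(=O)c2ccc(NC(=O)CBr)cc2)cc1` carries one change relative to compound 1, (methoxy in place of chloro on an aromatic carbon). In this assay compound 2 gives 46%, and the step is a number 13 percentage points lower from compound 1 to compound 2 (beyond the scatter). Compound 3 `CC(=O)c1ccc(OCC(=O)Nc2ccc(C(=O)/C=C/c3ccc(Cl)cc3)cc2)cc1` has a different core: the core of compound 3 differs from that of compound 1 by 4-acetylphenoxy in place of bromo on a saturated chain carbon bound to a carbonyl carbon. In this assay compound 3 gives 61%, and the step is a number 2 percentage points higher from compound 1 to compound 3 (within the scatter), so compound 3 and compound 1 are within the scatter of each other, while compound 3 stands beyond the scatter away from compound 2.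

Compound 4 `COc1ccc(/C=C/C(=O)c2ccc(NC(=O)COc3ccc(C(C)=O)cc3)cc2)cc1` has not been measured. It differs from compound 3 by methoxy in place of chloro on an aromatic carbon. This is the same change as from compound 1 to compound 2, at the same place on the ring; among the four compounds it occurs twice. For the measured compounds named here, the only measured instance of this change gave a number 13 percentage points lower from compound 1 to compound 2 (beyond the scatter), a modest fall, and that single pair is all the expectation can rest on. A step of about the same size is expected for compound 4, namely a number 13 percentage points lower from compound 3 to compound 4 (beyond the scatter). The estimate for compound 4 in this assay is therefore 48%, with a range from 36% to 60%.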

Compound 4, a percentage reported as inhibition, in the whole organism at one dose (the size of the read-out at that dose, not a potency): 42%
Compound 4: middle estimate off by 6 percentage points, on the high side; the measured number falls inside the stated range.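

In this assay, methoxy in place of chloro on the aromatic carbon gives a step that is a number 19 percentage points lower from compound 3 to compound 4 (beyond the scatter), and the two instances of this change agree: the same change on two cores in this assay, a number 13 percentage points lower (beyond the scatter) from compound 1 to compound 2 and a number 19 percentage points lower (beyond the scatter) from compound 3 to compound 4, 6 percentage points apart, within the scatter of two such steps The other change, 4-acetylphenoxy in place of bromo on the saturated chain carbon bound to the carbonyl carbon, gives a step that is a number 4 percentage points lower from compound 2 to compound 4 (within the scatter), and it too reads alike on both cores: the same change on two cores in this assay, a number 2 percentage points higher (within the scatter) from compound 1 to compound 3 and a number 4 percentage points lower (within the scatter) from compound 2 to compound 4, 6 percentage points apart, within the scatter of two such steps Within these four compounds each change therefore carries from one core to the other, with the fall on going from chloro to methoxy present with either the bromo or the 4-acetylphenoxy group on the chain, but this rests on two pairs at a single oral dose, so it shows neither a rule for other cores nor any reason for the fall.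

The compounds shown carry only chloro or methoxy on the aromatic ring and only bromo or 4-acetylphenoxy on the chain. On these data alone, it remains open whether the same steps would appear with a fluoro or dimethylamino group on that ring, or with a piperidine amine or a carboxylic acid on the chain in place of these groups.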